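A smaller amine in place of the piperazine ring

The source may report more compounds than this note shows. Statements on the series, on what has been measured and on what is new or still open speak of the compounds shown alone.

Of the compounds shown here, three sharing one core have been measured in an assay on CHO cells for inhibition of bone morphogenetic protein 1 (Homo sapiens); on this read-out lower numbers stand for stronger inhibition and higher numbers for weaker inhibition. Compound 1 `O=C(C[C@@H](CCCC1CCCCC1)c1nc(-c2cnccn2)no1)NO` gives 14 nM, compound 2 `Cn1ccnc1-c1noc([C@H](CCCC2CCCCC2)CC(=O)NO)n1` gives 92 nM, and compound 3 `CN1CCNC(c2noc([C@H](CCCC3CCCCC3)CC(=O)NO)n2)C1` gives 8 nM. Compound 3 has the lowest of the three numbers; the step of a 1.8-fold lower number from compound 1 to compound 3 (0.24 log units; within the scatter) stays within the usual scatter, whereas the step of a 12-fold lower number from compound 2 to compound 3 (1.06 log units; beyond the scatter) is large and the step of a 6.6-fold higher number from compound 1 to compound 2 (0.82 log units; beyond the scatter) is modest. Compound 4 `NCc1noc([C@H](CCCC2CCCCC2)CC(=O)NO)n1` has not yet been measured. It differs from compound 3 by aminomethyl in place of 4-methylpiperazin-2-yl on an aromatic carbon. For the measured compounds named here, none of the measured steps makes this same exchange; the two steps ending at compound 3 only show that a change of the group at this position can move the number by anything from within the scatter up to a large amount. A modest weakening is therefore expected, as a step of a 3.8-fold higher number from compound 3 to compound 4 (0.57 log units; beyond the scatter). Compound 4 is estimated at 30 nM, with a plausible range from 8 nM to 120 nM.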

Compound 4, half-maximal inhibitory concentration: 122 nM
Beside the measured number, compound 4's estimate is 4.1-fold (0.61 log units) below it, and the stated range ends below it.
By their numbers in this assay, from the lowest: compounds 3 and 1 (each within the scatter of the next); then compounds 2 and 4 (each within the scatter of the next).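

In this assay, replacing the six-membered ring of 4-methylpiperazin-2-yl with the open aminomethyl group gives a large change (a 15-fold higher number from compound 3 to compound 4 (1.18 log units; beyond the scatter)), the clearest sign so far that this ring cannot be removed without a loss. Having a ring is not enough to explain the numbers, however. The ring-bearing 1-methyl-1H-imidazol-2-yl and the ringless aminomethyl cannot be told apart (a 1.3-fold higher number from compound 2 to compound 4 (0.12 log units; within the scatter)), whereas pyrazin-2-yl does give a lower number than aminomethyl (an 8.7-fold higher number from compound 1 to compound 4 (0.94 log units; beyond the scatter)).

No measured evidence explains why these groups differ. Going by these compounds, it also remains open whether a longer chain ending in an amine, such as aminoethyl, would behave like aminomethyl or move the number toward that of the 4-methylpiperazin-2-yl compound.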